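Moving the ring nitrogen in a urea-linked bicyclic antagonist

This account rests on a few compounds, and the source may have more. Where it says the series, first, only, none or still open, it means among the compounds named here.

Compound 1: `CN(C)C1(Cc2ccccc2)CCN(c2cc(C(F)(F)F)ccc2CNC(=O)Nc2cccc3c(=O)[nH]ccc23)CC1` gives "not active" (no number reported)
Compound 2: `CN(C)C1(Cc2ccccc2)CCN(c2cc(C(F)(F)F)ccc2CNC(=O)Nc2ccc3cccnc3c2)CC1` gives 42 nM

In an assay on CHO cells for antagonist activity at transient receptor potential cation channel subfamily V member 1 (Homo sapiens), read by scintillation counting, with a stated time of 5 min, in the presence of a further agent that is not named here (on this read-out higher numbers stand for an effect only at larger amounts of compound and lower numbers for an effect already at smaller amounts), compound 1 is reported as "not active" (no number reported), so no number is available for it. Going by the values given here, compound 2, measured in this assay, gives 42 nM, the only numeric value in this set. Compound 3 is `CN(C)C1(Cc2ccccc2)CCN(c2cc(C(F)(F)F)ccc2CNC(=O)Nc2ccc3ccncc3c2)CC1`; it differs from compound 2 by isoquinolin-7-yl in place of quinolin-7-yl on an amide-type nitrogen. Among the compounds with values here, no measured pair shows the effect of this change, so the expected step of a 2.4-fold higher number from compound 2 to compound 3 (0.38 log units; beyond the scatter) is uncertain, with a modest loss thought slightly more likely than a gain. Compound 3 is therefore estimated at 100 nM, within a range of 25 nM to 600 nM.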

Compound 3, half-maximal effective concentration: 56.1 nM
Beside the measured number, compound 3's estimate is 1.8-fold (0.25 log units) above it; measured number inside the range.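

In this assay, isoquinolin-7-yl in place of quinolin-7-yl on the amide-type nitrogen gives a 1.3-fold higher number from compound 2 to compound 3 (0.13 log units; within the scatter), so compound 2 and compound 3 cannot be told apart. This first measured pair at this position shows that the ring nitrogen can occupy either of these two places while the number stays within the usual scatter. Nothing measured here explains this result. Going by these compounds, it remains open whether the ring nitrogen is needed at all, which a carbon-only naphthalen-2-yl group at the same place would test.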